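Replacing a hydroxymethyl piperidine with an ethyl piperidine

The compounds below may be only part of what the source reports. "The series", "measured", "known", "first", "only" and "open" are said of these compounds alone.

Of the compounds shown here, two built on a shared core have been measured in an assay on HEK293 cells for displacement of a labelled ligand from NPC1-like intracellular cholesterol transporter 1 (Homo sapiens); on this read-out higher numbers stand for weaker inhibition and lower numbers for stronger inhibition. Compound 1 `CC(C)(C)OC(=O)NCC1CCCN(C(=O)CN2CN(c3ccccc3)C3(CCN(C(=O)c4ccc(C5CCCCC5)cc4)CC3)C2=O)C1` gives 3800 nM in this assay, and compound 2 `O=C(CN1CN(c2ccccc2)C2(CCN(C(=O)c3ccc(C4CCCCC4)cc3)CC2)C1=O)N1CCC(CO)CC1` gives 1100 nM, the lower of the two numbers, with compound 1 standing beyond the usual scatter above it. Compound 3 `CCC1CCCN(C(=O)CN2CN(c3ccccc3)C3(CCN(C(=O)c4ccc(C5CCCCC5)cc4)CC3)C2=O)C1` has not yet been measured. It differs from compound 2 in one place: 3-ethylpiperidin-1-yl in place of 4-(hydroxymethyl)piperidin-1-yl on a carbonyl carbon. Among the measured compounds shown here, no step between two measured compounds matches this change, so there is no measured guide for its size. Since compound 1, which carries a larger substituted group at the same place, gives 3800 nM, a move toward a weaker number is expected for compound 3, but one that need not go beyond the scatter. The expected step from compound 2 to compound 3 is a 1.5-fold higher number from compound 2 to compound 3 (0.16 log units; within the scatter). Compound 3 is therefore estimated at 1600 nM in this assay, with a range from 500 nM to 5000 nM.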

Compound 3, half-maximal inhibitory concentration: 2600 nM
Beside the measured number, compound 3's estimate is 1.6-fold (0.21 log units) below it; measured number inside the range.
By their numbers in this assay, from the lowest: compound 2; then compounds 3 and 1 (each within the scatter of the next).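

In this assay this position proves sensitive to the exchange: the change gives a 2.4-fold higher number from compound 2 to compound 3 (0.37 log units; beyond the scatter), a modest step, although the entering and leaving groups have the same number of heavy atoms. That step combines a change of ring position with a change of group, and the data do not separate the two. The step of a 1.5-fold lower number from compound 1 to compound 3 (0.16 log units; within the scatter) lies within the scatter, so methyl in place of (tert-butoxycarbonyl)amino on a saturated chain carbon bound to a saturated ring carbon shows no readable difference, and nothing given here explains either result.

The compounds shown leave open whether 4-ethylpiperidin-1-yl or 3-(hydroxymethyl)piperidin-1-yl would separate ring position from the group itself. They also leave open how a piperidine carrying an aminomethyl group or a carboxylic acid would read.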